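One Stereocentre Inverted Between Compound 2 and Compound 4

This account rests on a few compounds, and the source may have more. Where it says the series, first, only, none or still open, it means among the compounds named here.

Compound 2 `C[C@@H]1O[C@@]1(C)Cc1cc(=O)n(C)c(=O)n1C` gives 89000 nM in a functional assay for inhibition, with Mus musculus as the target (on this read-out higher numbers stand for lower toxicity in this test and lower numbers for higher toxicity in this test), the highest of the two numbers measured here. Its nearest neighbour is compound 1 `Cn1c(CC2(C)CO2)cc(=O)n(C)c1=O`, which in this assay gives 4000 nM; the step of a 22-fold higher number from compound 1 to compound 2 (1.35 log units; beyond the scatter) came with 2,3-dimethyloxiran-2-yl in place of 2-methyloxiran-2-yl on a saturated chain carbon bound to an aromatic carbon. Compound 3 `CCCOc1nc(CC2(c3ccccc3)CO2)cc(=O)n1C` reached only the limit of > 30000 nM in this assay. Compound 4 `C[C@H]1O[C@@]1(C)Cc1cc(=O)n(C)c(=O)n1C` differs from compound 2 only in configuration: the two compounds have the same atoms and bonds and differ only in configuration as drawn: 1 of 2 stereo elements differ; a stereocentre at a saturated ring carbon is drawn S in compound 2 and R in compound 4. Within the data shown here, the one measured step, a 22-fold higher number from compound 1 to compound 2 (1.35 log units; beyond the scatter), concerns an added methyl rather than configuration, so it offers no direct guide to an inversion. No step beyond the scatter is therefore expected, and compound 4 is estimated at 89000 nM, within 25000 nM to 300000 nM. The expected step is no change at the digits printed from compound 2 to compound 4 (within the scatter).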

Compound 4, half-maximal cytotoxic concentration: 89000 nM
Compound 4: the middle estimate sits on the measured number at the digits printed; low and high end bracket the measured number.
By their numbers in this assay, from the lowest: compound 1; then compounds 2 and 4 (each within the scatter of the next).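

In this assay, inverting the stereocentre at the saturated ring carbon gave no change at the digits printed from compound 2 to compound 4 (within the scatter), so the drawn configuration at this carbon does not separate compound 2 from compound 4. The change to 2,3-dimethyloxiran-2-yl from 2-methyloxiran-2-yl is therefore not tied to one drawn form, giving a 22-fold higher number from compound 1 to compound 4 (1.35 log units; beyond the scatter). The compounds shown leave open what inverting the other stereo element would do. They also leave open whether an ethyl group or an amine in place of the added methyl would hold the number of compound 2.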